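This account rests on a few compounds, and the source may have more. Where it says the series, first, only, none or still open, it means among the compounds named here.

Measured in an ADME assay on microsomes from liver (Rattus norvegicus) for metabolic stability, using NADPH; on this read-out higher numbers stand for fast clearance and lower numbers for slow clearance:
- compound 1 `CNC(=O)c1nc(Br)c(C(F)(F)F)cc1N`: 0.1 mL/min/kg
- compound 2 `Nc1cc(C(F)(F)F)c(Br)nc1C(=O)NCCC(F)(F)F`: 0.0558 mL/min/kg
- compound 3 `CC(O)CNC(=O)c1nc(Br)c(C(F)(F)F)cc1N`: 0.0377 mL/min/kg

Compound 3 sits with compound 2 at the low end of these three numbers. The measurements show a 1.5-fold lower number from compound 2 to compound 3 (0.17 log units; within the scatter), while the gap to the remaining compound is a 2.7-fold lower number from compound 1 to compound 3 (0.42 log units; beyond the scatter).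

The compound still to be measured, compound 4 `Nc1cc(C(F)(F)F)c(Br)nc1C(=O)NC[C@H](O)C(F)(F)F`, keeps the shared core and changes only the amide side chain. On a saturated chain carbon bound to an amide-type nitrogen, 2,2,2-trifluoro-1-hydroxyethyl stands in place of 1-hydroxyethyl (2,2,2-trifluoro-1-hydroxyethyl in place of 1-hydroxyethyl on a saturated chain carbon bound to an amide-type nitrogen).

Going by the values given here, no measured pair makes this exact swap, so the evidence is indirect. The nearest guide is the pair of steps involving 2,2,2-trifluoroethyl. Adding that group gave a 1.8-fold lower number from compound 1 to compound 2 (0.25 log units; within the scatter), and exchanging it for 1-hydroxyethyl gave the step within the scatter already noted. Among the compounds with values here, neither step exceeded the scatter, and the only step that did was modest. No step beyond the scatter is therefore expected in this assay, and no clear direction can be assigned.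

The expected change is a 1.1-fold higher number from compound 3 to compound 4 (0.03 log units; within the scatter). The estimated clearance of compound 4 is 0.04 mL/min/kg, with an expected range of 0.015 mL/min/kg to 0.1 mL/min/kg.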

Compound 4, clearance: 0.023 mL/min/kg
Compound 4: middle estimate off by 1.7-fold (0.24 log units), on the high side; low and high end bracket the measured number.
By their numbers in this assay, from the lowest: compounds 4, 3, 2 and 1 (each within the scatter of the next, the first and the last beyond it).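

In this assay, 2,2,2-trifluoro-1-hydroxyethyl in place of 1-hydroxyethyl on a saturated chain carbon bound to an amide-type nitrogen gives a step that stays within the scatter (a 1.6-fold lower number from compound 3 to compound 4 (0.21 log units; within the scatter)), so this swap leaves the clearance of compound 3 essentially unchanged. Going by these compounds alone, compound 4 also opens a reading the earlier compounds did not allow: set against compound 2, it isolates hydroxy in place of hydrogen on a saturated chain carbon bound to two saturated chain carbons, and that step lies beyond the scatter, though modest (a 2.4-fold lower number from compound 2 to compound 4 (0.38 log units; beyond the scatter)), while the full side chain in place of hydrogen gives the largest step, also modest (a 4.3-fold lower number from compound 1 to compound 4 (0.64 log units; beyond the scatter)). Nothing in the data given here explains why the clearance follows these side chains.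

From the compounds shown here alone, whether the step from hydrogen to hydroxy holds when an amine or a carboxylic acid stands in place of the hydroxy remains open, as does the effect of a longer chain carrying the same 3,3,3-trifluoro-2-hydroxypropyl end. The compounds shown also leave open how the opposite configuration at the defined stereocentre of compound 4 would read in this assay.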